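Cytotoxicity notes: N-aryl pyridazinone amides on hepatoma cells

The source may report more compounds than this note shows. Statements on the series, on what has been measured and on what is new or still open speak of the compounds shown alone.

Measured compounds:
compound 1 `Cc1cc(=O)n(-c2ccccc2OC(F)(F)F)nc1C(=O)Nc1ccc(Oc2ncnc3ccsc23)cc1` — 25000 nM
compound 2 `Cc1cc(=O)n(-c2cccc(F)c2)nc1C(=O)Nc1ccc(Oc2ncnc3ccsc23)cc1` — 10200 nM

Two compounds of the series have been run in a functional assay on HepG2 cells (Homo sapiens) for cytotoxicity, read by MTT assay, with a stated time of 72 h; on this read-out lower numbers stand for stronger inhibition and higher numbers for weaker inhibition. Compound 1 gives 25000 nM in this assay, while compound 2 gives 10200 nM. Going by the values given here, the one step between them, a 2.5-fold lower number from compound 1 to compound 2 (0.39 log units; beyond the scatter), comes from swapping the whole aryl group on the ring nitrogen. Among the compounds with values here, compound 2 thus stands at the lower of the two numbers, with compound 1 the only neighbour.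

Compound 3 `Cc1cc(=O)n(-c2ccc(F)c(F)c2)nc1C(=O)Nc1ccc(Oc2ncnc3ccsc23)cc1` is not yet measured. It differs from compound 2 by fluoro in place of hydrogen on an aromatic carbon. Within the data shown here, no measured step changes a single fluoro on this aryl group; the only step on record, from compound 1 to compound 2, replaces the entire substituent and was modest in size. The added fluoro is a far smaller change, so a step beyond the scatter is not expected in either direction.

Compound 3 is therefore estimated at 9000 nM in this assay, with a range of 4000 nM to 25000 nM, corresponding to an expected step of a 1.1-fold lower number from compound 2 to compound 3 (0.05 log units; within the scatter).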

Compound 3, half-maximal inhibitory concentration: 9230 nM
Estimate against measurement, compound 3: 1.0-fold (0.01 log units) below, and the stated range covers the measured number.
By their numbers in this assay, from the lowest: compounds 3 and 2 (each within the scatter of the next); then compound 1.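

Working notes, position on the N-aryl group: in this assay fluoro in place of hydrogen, on the aromatic carbon ortho to a fluoro group and para to a large group, gives a 1.1-fold lower number from compound 2 to compound 3 (0.04 log units; within the scatter) and so lies within the scatter, which means this single added fluoro on the 3-fluorophenyl group does not separate compound 3 from compound 2 on this read-out. The wider exchange of 2-(trifluoromethoxy)phenyl for 3,4-difluorophenyl gives a 2.7-fold lower number from compound 1 to compound 3 (0.43 log units; beyond the scatter) and stays beyond the scatter, a modest step that sits alongside a 2.5-fold lower number from compound 1 to compound 2 (0.39 log units; beyond the scatter) with both fluorinated aryl groups apart from compound 1 in the same direction. No supporting evidence is available to account for either step.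

The compounds shown leave open whether a group other than fluoro at this position, such as an amine, a carboxylic acid or a methoxy group, would move the number beyond the scatter. They also leave open how a plain phenyl group would compare, and whether a trifluoromethoxy group elsewhere on the aryl ring would read like compound 1.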